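The compounds below may be only part of what the source reports. "The series", "measured", "known", "first", "only" and "open" are said of these compounds alone.

Measured so far in an ADME assay on HepG2 cells (Homo sapiens) for cytotoxicity, read by luminescence, CellTiter-Glo and ATP content, with a stated time of 72 h; a lower number here means that less compound is needed, a higher number that more compound is needed for the effect:
Compound 1, `c1ccc(CCc2ccc3c(NCCCNCc4ccco4)ccnc3c2)cc1` — compound 1 gives 16000 nM.
Compound 2, `COc1cccc(CNCCCNc2ccnc3cc(Cc4cc(C)cc(C)c4)ccc23)c1O` — compound 2 gives 2680 nM.

Among the measured compounds shown here, of these two numbers, compound 1 holds the highest; the only neighbour, compound 2, lies below it by a gap that exceeds the usual scatter, so on the evidence at hand compound 1 needs the larger amount of material for the effect on these cells.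

Compound 3, `CCC(CC)c1ccc2c(NCCCNCc3ccco3)ccnc2c1`, is the next compound for this assay. It differs from compound 1 in one place: pentan-3-yl in place of phenethyl on an aromatic carbon. For the measured compounds named here, no measured pair shows this particular exchange, so the account has no step to lean on. Given that compound 1 sits at 16000 nM, the author expects the step of a 1.3-fold higher number from compound 1 to compound 3 (0.10 log units; within the scatter) to be modest, if anything toward a higher number, and likely within the scatter. Compound 3 is accordingly estimated at 20000 nM, with a range from 8000 nM to 50000 nM.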

Compound 3, half-maximal effective concentration: 6760 nM
For compound 3 the middle estimate is 3.0-fold (0.47 log units) above the measured one; measured number outside the range, below it.
By their numbers in this assay, from the lowest: compound 2; then compound 3; then compound 1.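

In this assay, the exchange of phenethyl for pentan-3-yl on this aromatic carbon gives a 2.4-fold lower number from compound 1 to compound 3 (0.37 log units; beyond the scatter), so what stands at this position changes the number by more than the scatter. The six-membered aromatic ring of carbon only in phenethyl is therefore not required for the effect on these cells, as pentan-3-yl, with no ring and fewer heavy atoms, gives the lower number. Nothing at hand accounts for the size or direction of this step.

Among the compounds shown here, the single step cannot separate the loss of the ring from the change in the number of heavy atoms, which a cyclohexyl group or a longer straight alkyl chain at this carbon could help to distinguish. It also leaves open how an amine or a carboxylic acid would behave at this position, and whether the exchange would give a similar step in compounds that differ elsewhere.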